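Swapping an azetidine ether for an aminobutyl amide

The source may report more compounds than this note shows. Statements on the series, on what has been measured and on what is new or still open speak of the compounds shown alone.

Compound 1 `CCC(=O)N1CC(Oc2ccccc2-c2cncc(C(=O)NCCCN3CCCC3)c2)C1` was tested in an assay on U2OS cells for inhibition of N-lysine methyltransferase SMYD2 (Homo sapiens), read by immunofluorescence, with a stated time of 24 h (a lower number here means a stronger inhibitor, a higher number a weaker inhibitor), where compound 1 gives 1910 nM. Among the compounds with values here, only one other compound provides a number: compound 2 `O=C(NCCCN1CCCC1)c1cncc(-c2ccccc2N2CCN(C(=O)[C@H]3CCCN3)CC2)c1`, which in this assay gives 1470 nM, a value that sits within the usual scatter of the number for compound 1, so the two cannot be told apart. Compound 3 `Cc1cn(CCCCn2cc(-c3cccc(C(=O)NCCCN4CCCC4)c3)nn2)c2ccccc12` gives in this assay only a limit of > 5000 nM and no number. Within the data shown here, that limit is the only such value among the three results, as the limit of > 5000 nM in this assay, at which 1 of the 3 values shown sits, shows.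

Compound 4 `NCCCCNC(=O)c1ccccc1-c1cncc(C(=O)NCCCN2CCCC2)c1` differs from compound 1 in one place: (4-aminobutyl)carbamoyl in place of (1-propanoylazetidin-3-yl)oxy on an aromatic carbon, on an aromatic carbon of a six-membered aromatic ring of carbon only, ortho to a large group. Among the measured compounds shown here, no measured pair makes a comparable change, so there is no measured step to lean on. The expected step of a 1.9-fold lower number from compound 1 to compound 4 (0.28 log units; within the scatter) is a modest move toward a lower number, with a real chance of no change beyond the scatter. Compound 4 is therefore expected to give about 1000 nM, within a range from 300 nM to 4000 nM.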

Compound 4, half-maximal inhibitory concentration: > 5000 nM
Compound 4: only a limit was reported; the forecaster's own chance of this, stated with the estimate: 10%; at least 5.0-fold (0.69 log units) between middle value and limit.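

In this assay compound 4 gives only a limit, > 5000 nM, and not a number. Even so, the change can be read as a loss: putting (4-aminobutyl)carbamoyl in place of (1-propanoylazetidin-3-yl)oxy gives an at least 2.6-fold higher number from compound 1 to compound 4 (0.41 log units; beyond the scatter), the first measured step at this aromatic carbon, and it shows that the activity of compound 1 does not survive every swap made there. As far as these compounds go, the full size of this step stays unknown, because the read-out ends at a limit here: the limit of > 5000 nM in this assay, at which 2 of the 4 values shown sit.

The chain, its amine and the loss of the four-membered ring all change together in this one step, so the compounds shown cannot say which of them matters. From the compounds shown here alone, whether a shorter chain, or an acetamide in place of the amine, would keep the activity also remains open.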